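From 4-methylpiperazin-1-yl to piperidin-1-yl on the shared core

The source may report more compounds than this note shows. Statements on the series, on what has been measured and on what is new or still open speak of the compounds shown alone.

Of the compounds shown here, three with a shared core have been measured in a functional assay on DU-145 cells (Homo sapiens) for antiproliferative activity, read by MTT assay; a lower number here means a stronger inhibitor, a higher number a weaker inhibitor. Compound 1 `c1ccc2c(c1)ccn2-c1nc(N2CCNCC2)nc2ccccc12` gives 12.5 ug/mL, compound 2 `c1ccc(N2CCN(c3nc(-n4ccc5ccccc54)c4ccccc4n3)CC2)cc1` gives 50 ug/mL, and compound 3 `CN1CCN(c2nc(-n3ccc4ccccc43)c3ccccc3n2)CC1` gives 20.8 ug/mL. Compound 3 cannot be told apart from compound 1, with a 1.7-fold higher number from compound 1 to compound 3 (0.22 log units; within the scatter), but it stands clear of compound 2, with a 2.4-fold lower number from compound 2 to compound 3 (0.38 log units; beyond the scatter).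

The unmeasured compound 4 `c1ccc2c(c1)ccn2-c1nc(N2CCCCC2)nc2ccccc12` carries piperidin-1-yl in place of 4-methylpiperazin-1-yl on an aromatic carbon. Within the data shown here, no measured step makes this exchange. The three available steps change only the group on an amine nitrogen in a ring, and none removes that nitrogen, so they bear on compound 4 only indirectly. The largest of them is modest, with a 4.0-fold higher number from compound 1 to compound 2 (0.60 log units; beyond the scatter). Taken together, they give no ground to expect a large move in this assay, and a step within the scatter is expected, with a slight lean to a higher number. The estimate is anchored on compound 3 at 20.8 ug/mL, and the expected step is a 1.3-fold higher number from compound 3 to compound 4 (0.10 log units; within the scatter). The measurement for compound 4 is expected to be about 26 ug/mL, within an estimated range of 12 ug/mL to 60 ug/mL.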

Compound 4, half-maximal inhibitory concentration: 50 ug/mL
Estimate against measurement, compound 4: 1.9-fold (0.28 log units) below; the measured number falls inside the stated range.
By their numbers in this assay, from the lowest: compounds 1 and 3 (each within the scatter of the next); then compounds 2 and 4 (each within the scatter of the next).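

The earlier steps shown here only changed the group on the amine nitrogen in the ring, whereas this exchange removes that nitrogen altogether: in this assay, piperidin-1-yl in place of 4-methylpiperazin-1-yl on the aromatic carbon between two ring nitrogen atoms gives a 2.4-fold higher number from compound 3 to compound 4 (0.38 log units; beyond the scatter). The same loss starting from piperazin-1-yl gives a 4.0-fold higher number from compound 1 to compound 4 (0.60 log units; beyond the scatter), so both compounds that keep the ring nitrogen with a hydrogen or a methyl on it, compound 1 and compound 3, stand clear of compound 4 by a margin beyond the scatter. The position is therefore sensitive to more than the substituent on that nitrogen, and the printed values show that compound 2 at 50 ug/mL and compound 4 at 50 ug/mL match, although one keeps the nitrogen and carries phenyl on it while the other lacks it.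

Nothing given here accounts for this step. As far as these compounds go, it remains open whether morpholin-4-yl, with a ring oxygen in place of the nitrogen, or an open-chain amine such as dimethylamino on this carbon would read like compound 1 and compound 3 or like compound 4.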